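The source may hold more compounds than are shown below. What is called first, only, known or untested is meant among the compounds shown, and "the series" means these compounds.

Three compounds measured in a functional assay on MIA PaCa-2 cells (Homo sapiens) for inhibition, read by MTT assay, with a stated time of 3 days (on this read-out lower numbers stand for stronger inhibition and higher numbers for weaker inhibition), set the scene. Compound 1 `CCOC(=O)C1CCCCN1S(=O)(=O)c1ccc(S(=O)(=O)N(CC)CC)cc1` returns only a limit: in this assay compound 1 gives > 10000 nM. Compound 2 `CCOC(=O)[C@@H]1CCCN(S(=O)(=O)c2ccc(S(=N)(=O)N(CC)CC)cc2)C1` likewise stops at a limit, with compound 2 giving > 10000 nM. Compound 3 `CC(C)c1noc(N2CCN(C(=O)[C@@H]3CCCN(S(=O)(=O)c4ccc(S(=O)(=O)C(C)C)cc4)C3)CC2)n1` is the closest relative of the compound in question, and it too reaches only a limit: compound 3 gives > 10000 nM. For the measured compounds named here, compound 3 therefore stands nowhere distinct among the values shown, since all three results sit at the limit of > 10000 nM in this assay, at which 3 of the 3 values shown sit, and no step between measured compounds can be drawn from them.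

Compound 4 `CCNS(=O)(=O)c1ccc(S(=O)(=O)N2CCC[C@@H](C(=O)N3CCN(c4nc(C(C)C)no4)CC3)C2)cc1` differs from compound 3 in one place: ethylamino in place of isopropyl on a sulfonyl sulfur. Going by the values given here, no measured step speaks to what such a change does here, and nothing in the values shown gives a direction to read from. The expectation is therefore that compound 4 stays at or near the limit, with no step beyond the scatter; the estimated step is a step that the limit leaves unreadable from compound 3 to compound 4. On that basis compound 4 is expected to give about 15000 nM in this assay, within a range from 5000 nM to 50000 nM, and most probably the assay will again report only a limit.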

Compound 4, half-maximal inhibitory concentration: > 10000 nM
Compound 4 gave a limit, no number; the forecaster's own chance of this, stated with the estimate: 85%; the middle value does not contradict the limit.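

For the compounds shown here, compound 3 and compound 4 each return a limit and not a number, so no step between them can be read: the limit of > 10000 nM in this assay, at which 4 of the 4 values shown sit.

The compounds shown leave open whether ethylamino in place of isopropyl on a sulfonyl sulfur changes inhibition at all, and which change to the shared core would give a measured number instead of a limit.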